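Working notes: from compound 2 to compound 3

The compounds below may be only part of what the source reports. "The series", "measured", "known", "first", "only" and "open" are said of these compounds alone.

Compound 1 `O=S(=O)(c1ccc(O)c2ncccc12)C1CCCC1` gives 1.8 L/kg here
Compound 2 `O=S(=O)(c1ccc(F)cc1)c1cc(F)c(O)c2ncccc12` gives 3.5 L/kg here

Among the measured compounds shown here, both numbers come from an ADME assay on the whole organism for pharmacokinetics, with Rattus norvegicus as the target (on this read-out higher numbers stand for wider distribution into tissues and lower numbers for narrower distribution), and are the only measurements so far. Compound 2 has the larger of the two numbers, but its gap to compound 1 lies within the scatter, so the pair cannot be ranked.

For the measured compounds named here, the next compound to be measured is compound 3 `O=S(=O)(c1cc(F)c(O)c2ncccc12)C1CCCC1` which has cyclopentyl in place of 4-fluorophenyl on a sulfonyl sulfur as its one difference from compound 2. Going by the values given here, no pair of measured compounds isolates this change, so the data give no direct size for it in this assay and the expectation remains loose. Among the compounds with values here, the only guide is the narrow spread between compound 1 at 1.8 L/kg and compound 2 at 3.5 L/kg so far. A small move towards lower numbers is expected, with nothing beyond the scatter. The expected step is a 1.5-fold lower number from compound 2 to compound 3 (0.18 log units; within the scatter) and it is an estimate only. For compound 3 the estimated value is 2.3 L/kg with an expected range from 1.2 L/kg to 4.4 L/kg in this read-out.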

Compound 3, volume of distribution at steady state: 0.41 L/kg
Estimate against measurement, compound 3: 5.6-fold (0.75 log units) above, outside the stated range (below it).
By their numbers in this assay, from the lowest: compound 3; then compounds 1 and 2 (each within the scatter of the next).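

In this assay, among the compounds shown here, the sulfonyl sulfur proves to be a place where the group carried matters: cyclopentyl in place of 4-fluorophenyl gives an 8.5-fold lower number from compound 2 to compound 3 (0.93 log units; beyond the scatter) and this step lies beyond the scatter, a size that no earlier pair could show. The second single change points the same way, since fluoro in place of hydrogen on an aromatic carbon gives a 4.4-fold lower number from compound 1 to compound 3 (0.64 log units; beyond the scatter) and this step also lies beyond the scatter, so with cyclopentyl on the sulfonyl sulfur that fluoro is not a silent change on this read-out. Nothing available on these compounds bears on what lies behind either step.

Cyclopentyl and 4-fluorophenyl differ at once in ring size, in aromatic character and in the fluorine they carry, so the step at the sulfonyl sulfur cannot yet be assigned to any one of these, and an unsubstituted phenyl or a cyclohexyl there would begin to separate them. On these data alone, it also stays open whether the fluoro step holds with 4-fluorophenyl on the sulfonyl sulfur, and where a group bearing an amine would fall on this read-out.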